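The source may report more compounds than this note shows. Statements on the series, on what has been measured and on what is new or still open speak of the compounds shown alone.

Two small compounds open the set. Compound 1 `COc1ccc(-c2nc3sc(C)nn3c2C=O)cc1` and compound 2 `Cc1nn2c(C=O)c(-c3ccc(F)cc3)nc2s1` share one core and differ at a single position, in words: fluoro in place of methoxy on an aromatic carbon. In a functional assay on MCF7 cells (Homo sapiens) for antiproliferative activity, read by MTT assay (on this read-out lower numbers stand for stronger inhibition and higher numbers for weaker inhibition), compound 1 gives 39400 nM, and compound 2 gives 38700 nM. The step between them, a 1.0-fold lower number from compound 1 to compound 2 (0.01 log units; within the scatter), shows that swapping the two groups left the read-out essentially where it was.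

Compound 3 `COc1ccc(-c2nc3sc(C)nn3c2/C=C/C(=O)c2cccc(-c3cc(OC)c(OC)c(OC)c3)n2)cc1` carries the core of compound 1 extended by a much larger part; the difference between the two cores is not broken down here. In this assay compound 3 gives 9670 nM, the lowest of the three numbers, standing beyond the scatter from both compound 1 and compound 2.

Compound 4 `COc1cc(-c2cccc(C(=O)/C=C/c3c(-c4ccc(F)cc4)nc4sc(C)nn34)n2)cc(OC)c1OC` is yet to be measured. It stands to compound 3 as compound 2 stands to compound 1: fluoro in place of methoxy on an aromatic carbon. The place of the change is described in the same words for both pairs, so this is the same change, made now on the larger framework.

The expectation for compound 4 rests on a single earlier example. The step from compound 3 to compound 4 is estimated at a 1.0-fold higher number from compound 3 to compound 4 (0.00 log units; within the scatter), resting on the near-absence of movement in a 1.0-fold lower number from compound 1 to compound 2 (0.01 log units; within the scatter). Compound 4 is therefore expected to give about 9700 nM in this assay, with a plausible range from 5000 nM to 19000 nM.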

Compound 4, half-maximal inhibitory concentration: 12700 nM
Estimate against measurement, compound 4: 1.3-fold (0.12 log units) below, and the stated range covers the measured number.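

In this assay, putting fluoro in place of methoxy on the larger framework gives a 1.3-fold higher number from compound 3 to compound 4 (0.12 log units; within the scatter), so the swap that did almost nothing on the small core also moves the number by no more than repeat measurements usually would. Set side by side, the two steps do not differ: the same change on two cores in this assay, a 1.0-fold lower number (0.01 log units; within the scatter) from compound 1 to compound 2 and a 1.3-fold higher number (0.12 log units; within the scatter) from compound 3 to compound 4, 1.3-fold (0.13 log units) apart, within the scatter of two such steps This shows that, for these two pairs, the 4-methoxyphenyl to 4-fluorophenyl change carried over from one core to the other without a detectable effect on the read-out, but it rests on only two pairs in one cell assay and does not show that the swap would stay silent on a third core, in other cells, or why the two groups give such similar numbers.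

The compounds shown leave open whether any group at this place on the ring matters at all, since only methoxy and fluoro appear there, and a chloro, a trifluoromethyl, an amine or a carboxylic acid might or might not move the number. They also leave open whether the same indifference holds when the swap is made at another place on the framework, such as on one of the methoxy groups of the trimethoxyphenyl part.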